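The source may report more compounds than this note shows. Statements on the series, on what has been measured and on what is new or still open speak of the compounds shown alone.

Compound 1, `Cc1cccc(OC2CCN(c3ccc(-n4ccnc4)nn3)CC2)c1`: 251 nM
Compound 2, `CC(C)c1nnc(-c2ccc(N3CCC(Oc4ccccc4C(F)(F)F)CC3)nn2)s1`: 8.8 nM

Both numbers come from an assay on microsomes from liver for inhibition of acyl-CoA desaturase 1 (Rattus norvegicus); on this read-out lower numbers stand for stronger inhibition and higher numbers for weaker inhibition. Compound 2 gives 8.8 nM, the lower of the two numbers, while compound 1 gives 251 nM, a gap that lies beyond the usual scatter. Among the measured compounds shown here, no pair of measured compounds that differ in only one place is available, so no measured step can guide the next comparison directly.

Compound 3, `Cc1nnc(-c2ccc(N3CCC(Oc4ccccc4C(F)(F)F)CC3)nn2)s1`, has not yet been measured. It differs from compound 2 by methyl in place of isopropyl on an aromatic carbon. For the measured compounds named here, with no comparable step on record, the size of the change in this assay is uncertain; the expectation is for a moderate rise in the number, a step of a 2.8-fold higher number from compound 2 to compound 3 (0.45 log units; beyond the scatter), rather than a move within the scatter. On that basis compound 3 is estimated at 25 nM, with a likely range from 6 nM to 100 nM.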

Compound 3, half-maximal inhibitory concentration: 2.3 nM
For compound 3 the middle estimate is 11-fold (1.04 log units) above the measured one; measured number below the stated range.
By their numbers in this assay, from the lowest: compound 3; then compound 2; then compound 1.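

In this assay, among the compounds shown here, this is the first comparison between compounds that differ in only one place. Replacing 5-isopropyl-1,3,4-thiadiazol-2-yl with 5-methyl-1,3,4-thiadiazol-2-yl gives a 3.8-fold lower number from compound 2 to compound 3 (0.58 log units; beyond the scatter), so the number at this position responds to the alkyl group on the ring, and losing two carbons does not weaken inhibition but strengthens it modestly. Nothing measured here explains why the number falls with this change.

For the compounds shown here, with only two groups compared at this position, it remains open whether the number would keep falling with a bare hydrogen, or where an ethyl group, a cyclopropyl ring or an amine would fall. Going by these compounds alone, it also remains unknown whether the same change would have a similar effect with a different aryl ether on the piperidine, such as the one in compound 1.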